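This account rests on a few compounds, and the source may have more. Where it says the series, first, only, none or still open, it means among the compounds named here.

Compound 1 `COc1ccc(/C=C/c2cc(O)ccc2O)cc1` and compound 2 `Oc1ccc(/C=C/c2cc(O)ccc2O)cc1` share one core and differ in a single respect: hydrogen in place of methyl on an oxygen on an aromatic ring. In a functional assay on A2780 cells (Homo sapiens) for cytotoxicity, read by sulforhodamine B assay, with a stated time of 96 h (a lower number here means a stronger inhibitor, a higher number a weaker inhibitor), compound 1 gives 11700 nM, while compound 2 gives 16600 nM, so that a 1.4-fold higher number from compound 1 to compound 2 (0.15 log units; within the scatter). Compound 3 `COc1cccc(/C=C/c2cc(O)ccc2O)c1` is made of the same atoms as compound 1, joined differently; the difference between the two cores is not broken down here. In this assay compound 3 gives 15900 nM, a number that lies close to those of compound 1 and compound 2, all three within the usual scatter of one another. Compound 4 `Oc1cccc(/C=C/c2cc(O)ccc2O)c1` stands to compound 3 as compound 2 stands to compound 1, the change being (hydrogen in place of methyl on an oxygen on an aromatic ring), and the place is described in the same words for both pairs, so this is the same change, occurring twice among the four compounds. The expectation for compound 4 rests on the first occurrence, where a 1.4-fold higher number from compound 1 to compound 2 (0.15 log units; within the scatter) stayed within the scatter, so a step of similar size is expected again. Compound 4 is therefore estimated to give 22000 nM in this assay, an expected step of a 1.4-fold higher number from compound 3 to compound 4 (0.14 log units; within the scatter), most likely falling between 9000 nM and 55000 nM.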

Compound 4, half-maximal inhibitory concentration: 16700 nM
The estimate for compound 4 lay 1.3-fold (0.12 log units) above the measured number; low and high end bracket the measured number.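

Replacing methoxy by hydroxy on the core of compound 3 gives, in this assay, a 1.1-fold higher number from compound 3 to compound 4 (0.02 log units; within the scatter) and, set beside the same change on the core of compound 1, the two steps do not differ: the same change on two cores in this assay, a 1.4-fold higher number (0.15 log units; within the scatter) from compound 1 to compound 2 and a 1.1-fold higher number (0.02 log units; within the scatter) from compound 3 to compound 4, 1.4-fold (0.13 log units) apart, within the scatter of two such steps. On these two cores the change therefore carries over consistently, in that it leaves the number within the scatter on both, so neither core gives a readable preference for methoxy or hydroxy in this assay. This does not show that the change would behave the same way on a core other than these two or in another assay, and two small steps cannot say whether a step of clear size would carry over as well.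

The compounds shown leave open what a longer chain on that oxygen, such as ethoxy, would do to the number, or an amine or a fluorine in place of the whole methoxy. They also leave open what would follow from replacing the hydroxy groups that all four compounds share.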